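Swapping the Dihydroxyphenyl Group for 4-Bromophenyl

This account rests on a few compounds, and the source may have more. Where it says the series, first, only, none or still open, it means among the compounds named here.

In a functional assay on MCF7 cells (Homo sapiens) for inhibition, read by MTT assay, with a stated time of 72 h (on this read-out higher numbers stand for weaker inhibition and lower numbers for stronger inhibition), compound 1 (`COc1cc(OC)c(OC)cc1/C=C/C(=O)c1ccc(O)cc1O`) gives 33800 nM, the lower of the two numbers available, and stands beyond the scatter from compound 2 (`COc1cc(C(=O)/C=C/c2cc(OC)c(OC)cc2OC)ccc1O`), which gives 95500 nM. Compound 3 (`COc1cc(OC)c(OC)cc1/C=C/C(=O)c1ccc(Br)cc1`) carries 4-bromophenyl in place of 2,4-dihydroxyphenyl on a carbonyl carbon. For the measured compounds named here, no measured pair isolates this change, so the estimate rests on little. A small expected move toward stronger inhibition, not clearly beyond the scatter, is a 1.7-fold lower number from compound 1 to compound 3 (0.23 log units; within the scatter). In this assay the expected value for compound 3 is 20000 nM, with an estimated range from 5000 nM to 70000 nM.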

Compound 3, half-maximal inhibitory concentration: 18300 nM
The estimate for compound 3 lay 1.1-fold (0.04 log units) above the measured number, and the stated range covers the measured number.
By their numbers in this assay, from the lowest: compounds 3 and 1 (each within the scatter of the next); then compound 2.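

The swap to 4-bromophenyl gives a 1.8-fold lower number from compound 1 to compound 3 (0.27 log units; within the scatter) in this assay and so shows that 2,4-dihydroxyphenyl on a carbonyl carbon can give way to a ring with no hydrogen-bond donors or acceptors without a difference beyond the scatter. The earlier compounds shown here could not show this, since both carry hydroxyl groups on that ring. Nothing available offers a reason for this result.

The compounds shown leave open whether the bromine itself counts for anything. Plain phenyl, 4-chlorophenyl or 4-aminophenyl on the same carbonyl carbon would begin to answer that.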